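Removing the last methyl from a sulfonamide nitrogen

The source may report more compounds than this note shows. Statements on the series, on what has been measured and on what is new or still open speak of the compounds shown alone.

Measured so far:
- Compound 1 `COc1ccc(-c2cc(-c3ccc(S(=O)(=O)N(C)C)cc3)cnc2N)cn1` in a physicochemical assay for solubility, read by nephelometry, measured as kinetic solubility, at pH 2 (a higher number here means a more soluble compound, a lower number a less soluble compound), gives > 100 ug/mL. That reading is a limit of the assay, not a number.
- Compound 2 `CNS(=O)(=O)c1ccc(-c2cnc(N)c(-c3ccc(OC)nc3)c2)cc1` in this assay gives > 100 ug/mL. That reading too is a limit, not a number.

Compound 2 therefore stands at the upper edge of what this assay reports, and nothing finer can be said of its place. Going by the values given here, the one measured step that bears on the change studied here is a step that the two limits leave unreadable from compound 1 to compound 2. Both of its ends sit at the same limit, as the limit of > 100 ug/mL in this assay, at which 2 of the 2 values shown sit, records, so the size of that step, and even its direction, remain hidden.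

The step to compound 3 `COc1ccc(-c2cc(-c3ccc(S(N)(=O)=O)cc3)cnc2N)cn1` repeats the same kind of change on the remaining methyl: hydrogen in place of methyl on a sulfonamide nitrogen. Among the compounds with values here, since the only comparable step was unreadable, no size beyond the scatter can be expected in either direction; the expectation is simply that compound 3 remains at or past the limit, as compound 2 did with > 100 ug/mL. The estimate for compound 3 is therefore 120 ug/mL, with a range from 60 ug/mL to 250 ug/mL. The step this estimate implies is a step that the limit leaves unreadable from compound 2 to compound 3, which is expected to be within scatter.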

Compound 3, solubility: > 100 ug/mL
Compound 3 ended at the assay's limit; the forecaster's own chance of this, stated with the estimate: 80%; the middle value lies beyond the limit too.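

Going by these compounds alone, no step among compound 1, compound 2 and compound 3 can be read, because each reading is a limit and not a number: the limit of > 100 ug/mL in this assay, at which 3 of the 3 values shown sit.

The compounds shown leave open how far apart these three lie in this assay, and in which direction hydrogen in place of methyl on a sulfonamide nitrogen moves the reading.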